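Aryl Swap on a Shared Core: Expecting Little Change

The compounds below may be only part of what the source reports. "The series", "measured", "known", "first", "only" and "open" are said of these compounds alone.

Three compounds share one core and differ only in the aryl group on the amine nitrogen. In a functional assay on ECa-109 cells for inhibition, with ECa-109 cell line (Homo sapiens) as the target, read by sulforhodamine B assay (on this read-out lower numbers stand for stronger inhibition and higher numbers for weaker inhibition), compound 1 `COc1cccc(NC2=CC(=O)c3c(nc4n3[C@H]3OC[C@@H](O)[C@H]3OC4)C2=O)c1` gives 3340 nM, compound 2 `O=C1C(Nc2cccc(Cl)c2)=CC(=O)c2c1nc1n2[C@H]2OC[C@@H](O)[C@H]2OC1` gives 3080 nM, and compound 3 `Cc1ccc(NC2=CC(=O)c3c(nc4n3[C@H]3OC[C@@H](O)[C@H]3OC4)C2=O)cc1C` gives 4090 nM. Compound 3 cannot be set apart from the other two on these numbers: the steps of a 1.2-fold higher number from compound 1 to compound 3 (0.09 log units; within the scatter) and a 1.3-fold higher number from compound 2 to compound 3 (0.12 log units; within the scatter) both fall within the scatter, as does a 1.1-fold lower number from compound 1 to compound 2 (0.04 log units; within the scatter), so all three numbers stand together.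

Compound 4 `CCOc1ccccc1NC1=CC(=O)c2c(nc3n2[C@H]2OC[C@@H](O)[C@H]2OC3)C1=O` has not yet been measured. It differs from compound 3 in one place: 2-ethoxyphenyl in place of 3,4-dimethylphenyl on an amine nitrogen. For the measured compounds named here, the steps that bear on this change are the two earlier aryl exchanges on the same nitrogen, which were within the scatter, and the exchange of chloro for methoxy on an aromatic carbon, which was also within the scatter. Nothing in the shown numbers suggests that a 2-ethoxyphenyl group would behave differently from the aryl groups already tested. Compound 4 is therefore expected to give a number close to that of compound 3 in this assay, with an estimated step of a 1.1-fold lower number from compound 3 to compound 4 (0.03 log units; within the scatter) that stays within the scatter. The estimate for compound 4 is 3800 nM, between 1600 nM and 9000 nM.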

Compound 4, half-maximal inhibitory concentration: 4320 nM
Estimate against measurement, compound 4: 1.1-fold (0.06 log units) below, within the range that was stated.
By their numbers in this assay, from the lowest: compounds 2, 1, 3 and 4 (each within the scatter of the next).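

In this assay, the 2-ethoxyphenyl group on the amine nitrogen brings a change the earlier exchanges did not: it has 9 heavy atoms and 1 hydrogen-bond acceptor where 3,4-dimethylphenyl has 8 and 0, yet the step is a 1.1-fold higher number from compound 3 to compound 4 (0.02 log units; within the scatter). The comparisons with the other two aryl groups read the same way, with a 1.3-fold higher number from compound 1 to compound 4 (0.11 log units; within the scatter) and a 1.4-fold higher number from compound 2 to compound 4 (0.15 log units; within the scatter), so 2-ethoxyphenyl cannot be told apart from 3-methoxyphenyl, 3-chlorophenyl or 3,4-dimethylphenyl on these numbers. The flat picture from the first three compounds therefore extends to a fourth aryl group with a different name and substitution, and all four compounds stand together at this position on the amine nitrogen.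

Whether the numbers would stay together with a carboxylic acid or an amine on the aryl ring, or with a longer alkyl chain in place of the aryl group on the nitrogen, remains open, since every group shown here is a phenyl ring bearing chloro, methyl, methoxy or ethoxy. The data shown offer no measurement that would explain why these four values stand together.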